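Swapping the bicyclic aryl group on a somatostatin ligand

This account rests on a few compounds, and the source may have more. Where it says the series, first, only, none or still open, it means among the compounds named here.

Compound 1, `COC(=O)c1cc(CC(C)CN2C[C@@H]3CCCC[C@@H]3[C@H](C(=O)N3CCN(c4ccc([N+](=O)[O-])cc4)CC3)C2)cc(C(=O)OC)c1`: 398 nM
Compound 2, `COC(=O)c1cc(C[C@H](C)CN2C[C@@H]3CCCC[C@@H]3[C@H](C(=O)N3CCN(c4ccc([N+](=O)[O-])cc4)CC3)C2)cc(C(=O)OC)c1`: 933 nM
Compound 3, `C[C@@H](Cc1ccc2ocnc2c1)CN1C[C@@H]2CCCC[C@@H]2[C@H](C(=O)N2CCN(c3ccc(F)c(F)c3)CC2)C1`: 1620 nM

All three compounds were tested in an assay on isolated protein for binding affinity to somatostatin receptor type 1 (Homo sapiens); a higher number here means weaker binding, a lower number tighter binding. Compound 3 gives the highest number of the three, but only its gap to compound 1 lies beyond the usual scatter; compound 2 sits within the scatter of compound 3. Among the compounds with values here, the one step measured between compounds differing in a single place is the change from compound 1 to compound 2, a 2.3-fold higher number from compound 1 to compound 2 (0.37 log units; beyond the scatter), where the only difference is the fact that one of compounds 1 and 2 is drawn with a defined configuration and the other without, at the place where they differ.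

Compound 4, `Cc1cn2cc(C[C@H](C)CN3C[C@@H]4CCCC[C@@H]4[C@H](C(=O)N4CCN(c5ccc(F)c(F)c5)CC4)C3)ccc2n1`, differs from compound 3 by a group of 10 heavy atoms (8 carbon, 2 nitrogen; one five-membered aromatic ring with 2 hetero atoms, one six-membered aromatic ring with 1 hetero atom) in place of a group of 9 heavy atoms (7 carbon, 1 nitrogen, 1 oxygen; one five-membered aromatic ring with 2 hetero atoms, one six-membered aromatic ring of carbon only), on a saturated chain carbon, three bonds along the chain from an amine nitrogen in a ring. Within the data shown here, no measured step touches this kind of exchange: the step from compound 1 to compound 2 concerns a stereocentre, and compounds 1 and 2 differ from compound 3 in more than one place. There is therefore no basis for expecting a large move in this assay in either direction. Compound 4 is expected to give 1500 nM, with a range from 500 nM to 5000 nM. That estimate means an expected step of a 1.1-fold lower number from compound 3 to compound 4 (0.03 log units; within the scatter), within the scatter.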

Compound 4, dissociation constant: 39.8 nM
For compound 4 the middle estimate is 38-fold (1.58 log units) above the measured one; the whole stated range lies above it.
By their numbers in this assay, from the lowest: compound 4; then compound 1; then compounds 2 and 3 (each within the scatter of the next).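

In this assay, within the data shown here, the group on this saturated chain carbon turns out to matter a great deal: replacing 1,3-benzoxazol-5-yl with the entering group gives a 41-fold lower number from compound 3 to compound 4 (1.61 log units; beyond the scatter), whereas the only earlier step concerned a drawn configuration. The two groups have the same kinds of aromatic ring by size, the same counts of hydrogen-bond donors and acceptors, and no net charge, so these shared features do not separate them, while the step still shows that the read-out responds strongly to an exchange between two such similar groups. Nothing shown here explains this step.

This single exchange changes several things at once: the atom count, oxygen against nitrogen, and a hetero atom in the six-membered ring, and it cannot show which of them carries the step. On these data alone, how a plain phenyl group, or an amine or a carboxylic acid on the entering group, would behave at this place remains open.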